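A few compounds are considered here, and "the series" means these few. Any claim that something is new, unique, unknown or untested is made for them only; others in the source may bear on it.

Measured in a functional assay on NCI-H661 cells (Homo sapiens) for inhibition, read by MTT assay, with a stated time of 72 h; a lower number here means a stronger inhibitor, a higher number a weaker inhibitor:
- compound 1 `Nc1ccccc1NC(=O)c1ccc(CNCc2nc(-c3ccc(F)cc3)no2)cc1`: 4360 nM
- compound 2 `O=C(NO)c1ccc(CNCc2nc(-c3ccc(Cl)cc3)no2)cc1`: > 100000 nM (a limit, not a number)
- compound 3 `O=C(NO)c1ccc(CNCc2nc(-c3ccc([N+](=O)[O-])cc3)no2)cc1`: > 100000 nM (a limit, not a number)

Compound 3 has no number of its own, only a limit. It sits at the limit of > 100000 nM in this assay, at which 2 of the 3 values shown sit. Compound 4 `O=C(NO)c1ccc(CNCc2nc(-c3ccc(F)cc3)no2)cc1` differs from it at one place: fluoro in place of nitro on an aromatic carbon. In words, this is fluoro in place of nitro on an aromatic carbon, para to a large group.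

Within the data shown here, the one measured step at this place is a step that the two limits leave unreadable from compound 2 to compound 3, nitro in place of chloro, so it offers no size to carry over. No size or direction of change can therefore be read ahead in this assay, and compound 4 is expected to stay near the limit, quite possibly reported as a limit again. Compound 1, which also bears 4-fluorophenyl, reads 4360 nM, and that value keeps a lower result open.

The estimated step is a number no higher from compound 3 to compound 4 (the limit leaves the size open). For compound 4 the estimate is 100000 nM, with an expected range from 20000 nM to 300000 nM.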

Compound 4, half-maximal inhibitory concentration: > 100000 nM
Compound 4 ended at the assay's limit (the forecaster's own chance of this, stated with the estimate: 65%); the middle value lies on the limit itself.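

Compound 4 gives only a limit, > 100000 nM. The steps among compounds 2, 3 and 4 cannot be read, so fluoro, chloro and nitro on this aromatic carbon cannot be ranked while the hydroxy group sits on the amide-type nitrogen: the limit of > 100000 nM in this assay, at which 3 of the 4 values shown sit.

Among these compounds, with 4-fluorophenyl held constant, the one readable step in this assay comes from the other end of the molecule, and it is an at least 22-fold higher number from compound 1 to compound 4 (1.36 log units; beyond the scatter), with hydroxy in place of 2-aminophenyl on the amide-type nitrogen.

Still open, going by these compounds, is whether a methoxy group or an amine on this aromatic carbon would give a hydroxy compound a real number rather than a limit. Also open, on these data alone, is how chloro or nitro would read with 2-aminophenyl on the amide-type nitrogen, where values could be compared with that of compound 1.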